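The source may hold more compounds than are shown below. What is called first, only, known or untested is meant among the compounds shown, and "the series" means these compounds.

Measured compounds in an ADME assay on cells (Homo sapiens) for cytotoxicity, read by polymerase chain reaction, with a stated time of 3 days; on this read-out lower numbers stand for higher toxicity in this test and higher numbers for lower toxicity in this test:
compound 1 `Cc1nc(N(C)C)nc(N[C@@H]2C[C@H](CO)[C@@H](O)[C@H]2O)c1-c1nc2cnccc2s1` — 25000 nM
compound 2 `Cc1nc(NCc2c(F)cccc2F)nc(N[C@@H]2C[C@H](CO)[C@@H](O)[C@H]2O)c1-c1nc2cnccc2s1` — 4000 nM
compound 3 `Cc1nc(N(C)Cc2ccccc2)nc(N[C@@H]2C[C@H](CO)[C@@H](O)[C@H]2O)c1-c1nc2cnccc2s1` — 25000 nM

Compound 1 shares the highest number of the three with compound 3, the two being level at the digits shown; compound 2 lies furthest from it, with a 6.3-fold lower number from compound 1 to compound 2 (0.80 log units; beyond the scatter).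

Compound 4 `Cc1nc(N[C@@H](C)c2ccccc2)nc(N[C@@H]2C[C@H](CO)[C@@H](O)[C@H]2O)c1-c1nc2cnccc2s1` is not yet measured. Relative to compound 1 the change is (1-phenylethyl)amino in place of dimethylamino on an aromatic carbon.

Going by the values given here, two measured steps bear on this. Replacing dimethylamino with an arylmethyl-bearing amino that keeps a hydrogen on the nitrogen gave a 6.3-fold lower number from compound 1 to compound 2 (0.80 log units; beyond the scatter), a modest shift beyond the scatter. Adding a phenyl to the chain carbon while the nitrogen stays fully substituted gave no change at the digits printed from compound 1 to compound 3 (within the scatter), within the scatter; the same contrast appears as a 6.3-fold higher number from compound 2 to compound 3 (0.80 log units; beyond the scatter). Compound 4 resembles compound 2 in carrying a hydrogen on that nitrogen and a phenyl on the adjacent chain carbon, but lacks the fluorines, and it resembles compound 3 in the unsubstituted phenyl. A lower number than compound 1 is therefore expected, though likely smaller than the step to compound 2.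

For compound 4 the expected value is 10000 nM, with a range of 3500 nM to 30000 nM, which corresponds to an expected step of a 2.5-fold lower number from compound 1 to compound 4 (0.40 log units; beyond the scatter).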

Compound 4, half-maximal cytotoxic concentration: 25000 nM
For compound 4 the middle estimate is 2.5-fold (0.40 log units) below the measured one, within the range that was stated.
By their numbers in this assay, from the lowest: compound 2; then compounds 1, 3 and 4 (each within the scatter of the next).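

In this assay, a hydrogen on the nitrogen at this aromatic carbon does not by itself go with a lower number: (1-phenylethyl)amino in place of dimethylamino gives no change at the digits printed from compound 1 to compound 4 (within the scatter), and in place of benzyl(methyl)amino it gives no change at the digits printed from compound 3 to compound 4 (within the scatter). Compound 2 alone stands apart so far, with a 6.3-fold higher number from compound 2 to compound 4 (0.80 log units; beyond the scatter), so among the compounds shown the lower number goes with the 2,6-difluorobenzyl group, although that step changes the fluorines and the methyl of the 1-phenylethyl group together. No measurement available here accounts for this difference.

The compounds shown leave open whether the fluorines or the absence of that methyl carries the step from compound 2, a question that a plain benzylamino group and a 1-(2,6-difluorophenyl)ethylamino group at this carbon would separate. Also open, from the compounds shown here alone, is what the defined stereocentre of the 1-phenylethyl group contributes, which the mirror-image form of that group would test.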